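A few compounds are considered here, and "the series" means these few. Any claim that something is new, unique, unknown or untested is made for them only; others in the source may bear on it.

Measured so far:
compound 1 `O=c1cc(O)c2ccc(OCc3cccc(F)c3)cc2o1` gives 0% in an assay on isolated protein (strain Sprague-Dawley) for inhibition of Amine oxidase [flavin-containing] A (Rattus norvegicus), read by spectrophotometry, with a stated time of 5 min, tested at 10 uM; on this read-out higher numbers stand for more inhibition at the one concentration tested (going by the name of the read-out) and lower numbers for less inhibition;
compound 2 `CCOc1cc(=O)oc2cc(OCc3cccc(F)c3)ccc12` gives 25% in this assay;
compound 3 `CCOC(=O)COc1cc(=O)oc2cc(OCc3cccc(Cl)c3)ccc12` gives 0% in this assay.

The one change that is seen twice among these compounds is hydrogen in place of ethyl on an oxygen on an aromatic ring. Going that way it made a number 25 percentage points lower from compound 2 to compound 1 (beyond the scatter), so the ethyl group appears to matter, though this rests on a single pair. How the core of compound 3 differs from that of compound 2 is not broken down here. Compound 3 and compound 1 are level at the digits given, and together they stand lowest of the three.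

Compound 4 `O=C(O)COc1cc(=O)oc2cc(OCc3cccc(Cl)c3)ccc12` differs from compound 3 by hydrogen in place of ethyl on an oxygen next to a carbonyl group. This is the same kind of change as before, but not the same: in the earlier pair the oxygen sat on an aromatic ring with an aromatic carbon as its other neighbour, whereas here it sits next to a carbonyl group with a carbonyl carbon as its other neighbour. The same direction of effect is expected, a loss or no change rather than a gain, because compound 3 already gives 0% and there is no room for a further fall. Compound 4 is therefore expected to show a number 3 percentage points higher from compound 3 to compound 4 (within the scatter) in this assay, ending near 3%, between 0% and 15%.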

Compound 4, a percentage reported as inhibition, at one concentration (the size of the read-out at that concentration, not a potency): 0%
Compound 4: the middle estimate sits 3 percentage points above what was measured; measured number inside the range.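

Hydrogen in place of ethyl on an oxygen next to a carbonyl group gave no change at the digits printed from compound 3 to compound 4 (within the scatter) in this assay. Set beside the earlier step, this change did not carry from one core to the other at the same size: the same change on two cores in this assay, a number 25 percentage points lower (beyond the scatter) from compound 2 to compound 1 and no change at the digits printed (within the scatter) from compound 3 to compound 4, 25 percentage points apart, beyond the scatter of two such steps This does not show that the core alone decides the outcome: the oxygen carrying the ethyl sits on an aromatic ring in one pair and next to a carbonyl group in the other, and compound 3 starts at 0%, which leaves no room for a fall.

The compounds shown leave open whether a longer chain or an amine-bearing chain on the oxygen of the core of compound 2 would take the number above that of ethyl. They also leave open whether an amide in place of the ester of compound 3 would give any measurable inhibition at all.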